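The compounds below may be only part of what the source reports. "The series", "measured", "known", "first", "only" and "open" are said of these compounds alone.

Compound 1 `COc1ccc(Cn2cc(/C=N\NC(=O)c3c[nH]c4ccccc34)c3ccccc32)cc1` gives 15100 nM in a functional assay on MDA-MB-231 cells (Homo sapiens) for cytotoxicity; on this read-out higher numbers stand for weaker inhibition and lower numbers for stronger inhibition. Compound 2 `Cn1cc(C(=O)N/N=C\c2cn(Cc3ccc(Cl)cc3)c3cc(F)ccc23)c2ccccc21` gives > 100000 nM in this assay, which is a limit of the assay and not a number.

Compound 2 therefore stands at the limit of > 100000 nM in this assay, at which 1 of the 2 values shown sits, so only an upper bound on its strength is known. Compound 3 `O=C(N/N=C\c1cn(Cc2ccc(Cl)cc2)c2cc(F)ccc12)c1c[nH]c2ccc(Br)cc12` differs from compound 2 in one place: 5-bromo-1H-indol-3-yl in place of 1-methyl-1H-indol-3-yl on a carbonyl carbon. Among the compounds with values here, no measured pair shows this change alone, so its effect is unknown. A modest step toward stronger inhibition, an at least 1.6-fold lower number from compound 2 to compound 3 (0.22 log units; that floor lies within the scatter), is the expectation, with the real chance that only a limit returns. Compound 3 is estimated at 60000 nM, between 15000 nM and 150000 nM.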

Compound 3, half-maximal inhibitory concentration: 5100 nM
Compound 3: the middle estimate sits 12-fold (1.07 log units) above what was measured; the measured number lies below the stated range.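

Within the data shown here, on a carbonyl carbon whose other neighbour is the amide-type nitrogen, the group matters in this assay: 5-bromo-1H-indol-3-yl in place of 1-methyl-1H-indol-3-yl gives an at least 19-fold lower number from compound 2 to compound 3 (1.29 log units; beyond the scatter), the first step here that can be read. That step is only a floor, as compound 2 stands at a limit: the limit of > 100000 nM in this assay, at which 1 of the 3 values shown sits.

On these data alone, the swap adds a bromine and removes the methyl together, so which of them carries the gain stays open. Also open, as far as these compounds go, is how a 5-amino-1H-indol-3-yl group would behave at this place.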